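The compounds below may be only part of what the source reports. "The series", "measured", "known", "first", "only" and "open" are said of these compounds alone.

Working notes on the series. Compound 1 `O=C(Nc1cc(C(F)(F)F)cc(C(F)(F)F)c1)c1ccc(Sc2ccc(O)cc2)cc1` gives 2390 nM in a functional assay on LNCaP cells (Homo sapiens) for antiproliferative activity, read by fluorescence and propidium iodide staining, with a stated time of 96 h (on this read-out lower numbers stand for stronger inhibition and higher numbers for weaker inhibition), and compound 2 `O=C(Nc1ccc(S(F)(F)(F)(F)F)cc1)c1ccc(Sc2ccc(O)cc2)cc1` gives 4860 nM. Going by the values given here, compound 3 `O=C(Nc1cc(C(F)(F)F)cc(C(F)(F)F)c1)c1ccc(S(=O)(=O)c2ccc(O)cc2)cc1` gives 8410 nM, the highest of the three numbers; its step of a 3.5-fold higher number from compound 1 to compound 3 (0.55 log units; beyond the scatter) is the only single-point change measured so far. The next compound, compound 4 `O=C(Nc1cccc(C(F)(F)F)c1)c1ccc(S(=O)(=O)c2ccc(O)cc2)cc1`, is hydrogen in place of trifluoromethyl on an aromatic carbon, on the aromatic carbon meta to the remaining trifluoromethyl group. Among the compounds with values here, no measured step in this assay covers the loss of a trifluoromethyl, and the gap between compound 1 and compound 2 mixes two changes, so it cannot be read as one. The direction is therefore open; a modest rise is expected for compound 4, a 1.4-fold higher number from compound 3 to compound 4 (0.15 log units; within the scatter), giving an estimate of 12000 nM with a range from 5000 nM to 30000 nM.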

Compound 4, half-maximal inhibitory concentration: 10200 nM
Compound 4: middle estimate off by 1.2-fold (0.07 log units), on the high side, and the stated range covers the measured number.
By their numbers in this assay, from the lowest: compound 1; then compounds 2, 3 and 4 (each within the scatter of the next, the first and the last beyond it).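

In this assay, hydrogen in place of trifluoromethyl on the aromatic carbon meta to a trifluoromethyl group gives a 1.2-fold higher number from compound 3 to compound 4 (0.08 log units; within the scatter). Going by these compounds alone, this is the first single-point reading at this position, and with a sulfonyl link the second trifluoromethyl group makes no difference beyond the scatter. Nothing at hand gives a reason for this result.

Going by these compounds, whether the same exchange reads alike with the sulfanyl link of compound 1 remains open. So does the effect of an amine, a nitrile or a carboxylic acid on this aromatic carbon.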